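Notes on a thiophenyl isomer swap in the urea series

A few compounds are considered here, and "the series" means these few. Any claim that something is new, unique, unknown or untested is made for them only; others in the source may bear on it.

The series shares a core carrying a urea-linked aromatic ring. Compound 1 `CC1(C)[C@H]2CC=C(CN3CCC(NC(=O)Nc4cc(C(F)(F)F)cc(C(F)(F)F)c4)CC3)[C@@H]1C2` bears two trifluoromethyl groups on that ring, and in a functional assay on CHO cells for antagonist activity at C-X-C chemokine receptor type 3 (Homo sapiens), read by GTPgammaS binding (a higher number here means a weaker inhibitor, a lower number a stronger inhibitor), compound 1 gives 73 nM. Compound 2 `CC1(C)[C@H]2CC=C(CN3CCC(NC(=O)Nc4cncc(Br)c4)CC3)[C@@H]1C2` carries a bromo group on a ring with one nitrogen, and compound 2 gives 171 nM. For the measured compounds named here, compound 3 `CC1(C)[C@H]2CC=C(CN3CCC(NC(=O)Nc4cncc(-c5cccs5)c4)CC3)[C@@H]1C2` carries thiophen-2-yl in place of that bromo, and compound 3 gives 70 nM; the step of a 2.4-fold lower number from compound 2 to compound 3 (0.39 log units; beyond the scatter) is the only measured step in the set. Compound 3 thus shows the lowest of the three numbers, although its gap to compound 1 lies within the scatter and only its gap to compound 2 lies beyond it.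

Compound 4 `CC1(C)[C@H]2CC=C(CN3CCC(NC(=O)Nc4cncc(-c5ccsc5)c4)CC3)[C@@H]1C2` differs from compound 3 in one place: thiophen-3-yl in place of thiophen-2-yl on an aromatic carbon. Going by the values given here, no measured step bears directly on this change; the one step available, a 2.4-fold lower number from compound 2 to compound 3 (0.39 log units; beyond the scatter), concerns the arrival of a thiophenyl group rather than its point of attachment, and here the same atoms are merely joined differently. The step of a 1.1-fold higher number from compound 3 to compound 4 (0.06 log units; within the scatter) is therefore expected to stay within the scatter, with no clear direction. Compound 4 is estimated at 80 nM, with a range from 35 nM to 180 nM.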

Compound 4, inhibition constant: 107 nM
The estimate for compound 4 lay 1.3-fold (0.13 log units) below the measured number; measured number inside the range.
By their numbers in this assay, from the lowest: compounds 3, 1, 4 and 2 (each within the scatter of the next, the first and the last beyond it).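

In this assay, moving the point of attachment of the thiophene gives a 1.5-fold higher number from compound 3 to compound 4 (0.18 log units; within the scatter), so the compounds shown do not separate thiophen-2-yl from thiophen-3-yl at this position, two atoms from the ring nitrogen. Against bromo, the picture is less firm than compound 3 alone suggested: thiophen-3-yl gives a 1.6-fold lower number from compound 2 to compound 4 (0.20 log units; within the scatter), whereas thiophen-2-yl gives a 2.4-fold lower number from compound 2 to compound 3 (0.39 log units; beyond the scatter), so only the latter step clears the scatter, even though the two thiophenes themselves cannot be told apart. Nothing available accounts for this small difference between the two isomers.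

The compounds shown leave open whether the position tolerates aromatic rings other than thiophene, such as phenyl or furan-2-yl. They also leave open how it responds to a non-aromatic substituent, such as an amine or a carboxylic acid.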